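A few compounds are considered here, and "the series" means these few. Any claim that something is new, unique, unknown or untested is made for them only; others in the source may bear on it.

Measured compounds:
- Compound 1 `Cn1cc(CO)c(N)nc1=O` in a functional assay on MIA PaCa-2 cells (Homo sapiens) for inhibition, read by MTT assay, with a stated time of 72 h (on this read-out higher numbers stand for weaker inhibition and lower numbers for stronger inhibition), gives > 100000 nM, which is a limit of the assay.
- Compound 2 `O=c1nc(NO)cc[nH]1` in this assay gives > 100000 nM, also a limit of the assay.
- Compound 3 `Cc1cc(=O)[nH]c(=O)n1COC(CO)CO` in this assay gives > 100000 nM, again a limit of the assay.

Compound 3 thus stands at the limit of > 100000 nM in this assay, at which 3 of the 3 values shown sit; no numerical value exists for it, and the two other compounds offer nothing beyond the same limit. For the measured compounds named here, no pair of measured compounds differs in a single place, so no measured step is available.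

Compound 4 `O=c1ccn(COC(CO)CO)c(=O)[nH]1` is not yet measured. It differs from compound 3 by hydrogen in place of methyl on an aromatic carbon, in words hydrogen in place of methyl on an aromatic carbon.

With compound 3 sitting at the assay limit in this assay, the expected step from compound 3 to compound 4 is none beyond the scatter, and the most likely outcome is that compound 4 again returns only a limit. The estimate for compound 4 in this assay is 150000 nM, with a range from 50000 nM to 500000 nM, which corresponds to an expected step that the limit leaves unreadable from compound 3 to compound 4.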

Compound 4, half-maximal inhibitory concentration: > 100000 nM
Compound 4: a limit, no number; the forecaster's own chance of this, stated with the estimate: 85%; the middle value does not contradict the limit.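

No step can be read from compound 3 to compound 4, as both return only a limit in this assay: the limit of > 100000 nM in this assay, at which 4 of the 4 values shown sit.

The compounds shown leave open how hydrogen in place of methyl on an aromatic carbon would act on a numerical value in this assay.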